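Plasma unbound fraction across a piperidinyl triazolopyridine series

The source may hold more compounds than are shown below. What is called first, only, known or untested is meant among the compounds shown, and "the series" means these compounds.

Measured so far:
compound 1, `COc1ccc(F)cc1C1CCN(c2ccn3c(CC(F)(F)F)nnc3c2Cl)CC1`: in an ADME assay on a cell-free system (plasma, Rattus norvegicus) for protein binding (a higher number here means a larger unbound share of the compound, a lower number a smaller unbound share), compound 1 reports only a limit, < 0.01.
compound 2, `COc1ccccc1C1CCN(c2ccn3c(CC4CC4)nnc3c2Cl)CC1`: in this assay compound 2 reports only a limit, < 0.01.

Compound 2 therefore stands at the floor of what this assay resolves; its value is a limit and not a number, and (the limit of < 0.01 in this assay, at which 2 of the 2 values shown sit). Compound 3, `COc1ccc(F)cc1C1CCN(c2ccn3c(CC4CC4)nnc3c2Cl)CC1`, carries fluoro in place of hydrogen on an aromatic carbon, fluoro in place of hydrogen on an aromatic carbon. Going by the values given here, no measured step covers this change. In this assay no movement beyond the scatter is expected, and compound 3 is expected to remain at the limit, a step that the limit leaves unreadable from compound 2 to compound 3. For compound 3 the estimate is 0.005, in the range 0.002 to 0.012.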

Compound 3, unbound fraction: < 0.01
Compound 3 was reported as a limit; the forecaster's own chance of this, stated with the estimate: 85%; the middle value lies beyond the limit too.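

Going by these compounds alone, no step from compound 1 or compound 2 to compound 3 can be read in this assay, as all three compounds report only a limit: the limit of < 0.01 in this assay, at which 3 of the 3 values shown sit. The compounds shown leave open whether either change alters the unbound fraction, and how far each true value lies beyond the limit.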